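Cyclopropyl for Trifluoromethoxy on the Aryl Ring of Compound 1

The compounds below may be only part of what the source reports. "The series", "measured", "known", "first", "only" and "open" are said of these compounds alone.

Of the compounds shown here, three sharing one spirocyclic core have been measured in an assay on membranes from liver for displacement of a labelled ligand from Glucagon receptor (Mus musculus), read by scintillation counting, with a stated time of 60 min; a higher number here means a weaker inhibitor, a lower number a stronger inhibitor. Compound 1 `C[C@H](c1ccc(C(=O)NCCC(=O)O)cc1)N1C(=O)C(c2cccc(OC(F)(F)F)c2)=N[C@]12CC[C@@H](C(C)(C)C)CC2` gives 1500 nM. Compound 3 `CC(C)(C)CC[C@H](c1ccc(C(=O)NCc2nn[nH]n2)cc1)N1C(=O)C(c2cnccc2C(F)(F)F)=N[C@]12CC[C@@H](C(C)(C)C)CC2` gives 96 nM, which is the stronger of the two numbers; the value of compound 1 is the highest of the two, and its nearest neighbour, compound 3, sits well beyond the usual scatter. Compound 2 `CC(C)(C)[C@H]1CC[C@]2(CC1)N=C(c1ccc(Cl)cc1)C(=O)N2Cc1ccc(C(=O)NCCC(=O)O)cc1` reaches only the limit of this assay, > 10000 nM, and no number is known for it (the limit of > 10000 nM in this assay, at which 1 of the 3 values shown sits).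

Compound 4 `C[C@H](c1ccc(C(=O)NCCC(=O)O)cc1)N1C(=O)C(c2cccc(C3CC3)c2)=N[C@]12CC[C@@H](C(C)(C)C)CC2` has not yet been measured. It differs from compound 1 in a single place: cyclopropyl in place of trifluoromethoxy on an aromatic carbon. Among the compounds with values here, nothing among the measured compounds tests this exact exchange, since no pair differs in one place only, so the account can lean on no measured step for it. Neither direction has support in the shown numbers.

Compound 4 is therefore expected to stay close to compound 1, with a step of no change at the digits printed from compound 1 to compound 4 (within the scatter) that is not expected to exceed the usual scatter. The estimate for compound 4 in this assay is 1500 nM, with a range from 500 nM to 4500 nM.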

Compound 4, half-maximal inhibitory concentration: 1700 nM
Estimate against measurement, compound 4: 1.1-fold (0.05 log units) below; the range from low to high includes it.
By their numbers in this assay, from the lowest: compound 3; then compounds 1 and 4 (each within the scatter of the next). At a limit, above all of these: compound 2.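

Cyclopropyl in place of trifluoromethoxy on an aromatic carbon, meta to a large group, gives a 1.1-fold higher number from compound 1 to compound 4 (0.05 log units; within the scatter) in this assay, and this is the only step among the compounds shown that differs in one place. It shows that at this position the assay does not separate the two groups, although trifluoromethoxy, with its 5 heavy atoms and 1 hydrogen-bond acceptor, and cyclopropyl, with its 3 heavy atoms and no hydrogen-bond acceptor, differ in size, in atoms and in having a ring. Nothing in the evidence at hand bears on why the two groups read alike.

From the compounds shown here alone, whether the position responds to groups of another kind, such as an amine, a carboxylic acid or a longer alkyl chain, remains open, since both groups compared here leave the number in the same place. Going by these compounds, it is also open whether the same exchange would read alike on the background of compound 3, which differs from compound 1 in more than one place and so offers no direct comparison.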